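The source may hold more compounds than are shown below. What is called first, only, known or untested is meant among the compounds shown, and "the series" means these compounds.

Compound 1 `CCN1CC(NC(=O)[C@@H]2CCCN(S(=O)(=O)c3ccc(S(=O)(=O)N(CC)CC)cc3)C2)C1`: in a functional assay on MIA PaCa-2 cells (Homo sapiens) for inhibition, read by MTT assay, with a stated time of 3 days (a higher number here means a weaker inhibitor, a lower number a stronger inhibitor), compound 1 gives > 10000 nM, which is a limit of the assay and not a number.
Compound 2 `CCN(CC)S(=O)(=O)c1ccc(S(=O)(=O)N2CCC[C@@H](C(=O)NC3COC3)C2)cc1`: in this assay compound 2 gives 900 nM.
Compound 3 `CCN(CC)S(=O)(=O)c1ccc(S(=O)(=O)N2CCC[C@@H](C(=O)NC3CN(C(=O)NC(C)(C)C)C3)C2)cc1`: in this assay compound 3 gives 1400 nM.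

Among the two numbers that were measured, compound 2 has the lower one; its nearest neighbour is compound 3, with a 1.6-fold higher number from compound 2 to compound 3 (0.19 log units; within the scatter), so the two cannot be placed in an order. Compound 1 sits at the limit of > 10000 nM in this assay, at which 1 of the 3 values shown sits, so the steps from it are only floors: an at least 11-fold lower number from compound 1 to compound 2 (1.04 log units; beyond the scatter), and an at least 7.1-fold lower number from compound 1 to compound 3 (0.85 log units; beyond the scatter).

Compound 4 `CCN(CC)S(=O)(=O)c1ccc(S(=O)(=O)N2CCC[C@@H](c3cc(C)no3)C2)cc1` differs from compound 2 in one place: 3-methyl-1,2-oxazol-5-yl in place of (oxetan-3-yl)carbamoyl on a saturated ring carbon. Among the compounds with values here, none of the measured steps removed the carbonyl link on that ring carbon; the one step between two numbers, from compound 2 to compound 3, swapped one group on the amide-type nitrogen for another and stayed within the scatter. That gives no direct guide for putting an aromatic ring straight onto the saturated ring carbon, so the expected change is uncertain in direction and the estimate is wide. The step from compound 2 to compound 4 is estimated as a 1.7-fold higher number from compound 2 to compound 4 (0.22 log units; within the scatter). Compound 4 is therefore expected to give about 1500 nM in this assay, with a range from 300 nM to 8000 nM.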

Compound 4, half-maximal inhibitory concentration: 2700 nM
Beside the measured number, compound 4's estimate is 1.8-fold (0.26 log units) below it; measured number inside the range.
By their numbers in this assay, from the lowest: compounds 2, 3 and 4 (each within the scatter of the next, the first and the last beyond it). At a limit, above all of these: compound 1.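

Within the data shown here, compound 4 is the first compound here in which the whole carbamoyl link on the saturated ring carbon is gone, with the 3-methyl-1,2-oxazol-5-yl ring sitting directly on that carbon. In this assay, this exchange gives a 3.0-fold higher number from compound 2 to compound 4 (0.48 log units; beyond the scatter), a modest step, whereas the swap on the amide-type nitrogen that links compound 2 and compound 3 stayed within the scatter, so this position responds to the loss of the whole link, but compound 4 still gives a measured number without any amide at this carbon. Compound 1 stands at a limit and not a number, so an at least 3.7-fold lower number from compound 1 to compound 4 (0.56 log units; beyond the scatter) is only a floor: the limit of > 10000 nM in this assay, at which 1 of the 4 values shown sits.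

With a single replacement for the carbamoyl link, the compounds shown cannot separate the effect of losing the amide from the effect of this particular ring. Going by these compounds, a phenyl ring, a 1,2-oxazol-5-yl ring without the methyl, or a methylene spacer between the saturated ring carbon and the 3-methyl-1,2-oxazol-5-yl ring would each help to tell these apart, and how any of them would fare remains open.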